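Removing a methyl from an oxygen in three chalcones

A few compounds are considered here, and "the series" means these few. Any claim that something is new, unique, unknown or untested is made for them only; others in the source may bear on it.

Of the compounds shown here, three have been tested in an ADME assay on RAW264.7 cells (Mus musculus) for cytotoxicity, read by MTT assay, with a stated time of 24 h, tested at 5 ug/mL; on this read-out lower numbers stand for a stronger effect and higher numbers for a weaker effect at the one concentration tested. Compound 3 `COc1ccc(/C=C/C(=O)c2cccc(O)c2)cc1OC` gives 83.8%, compound 2 `COc1ccc(/C=C/C(=O)c2ccc(OC)c(OC)c2)cc1` gives 78.9%, and compound 1 `COc1cc(/C=C/C(=O)c2cccc(O)c2)ccc1O` gives 63.8%. Compound 1 is made from compound 3 by one change, (hydrogen in place of methyl on an oxygen on an aromatic ring), and this brings a number 20 percentage points lower from compound 3 to compound 1 (beyond the scatter). How the core of compound 2 differs from the core of compound 3 is not broken down here. Compound 4 `COc1ccc(/C=C/C(=O)c2ccc(O)c(OC)c2)cc1` is not yet measured; it is made from compound 2 by the same change, (hydrogen in place of methyl on an oxygen on an aromatic ring). Because the earlier step of a number 20 percentage points lower from compound 3 to compound 1 (beyond the scatter) was modest but beyond the scatter, a step of about a number 16.9 percentage points lower from compound 2 to compound 4 (beyond the scatter) is expected from compound 2 to compound 4, though it rests on a single example. Compound 4 is therefore estimated at 62% in this assay, within a range from 48% to 78%.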

Compound 4, a percentage reported as activity, at one concentration (the size of the read-out at that concentration, not a potency): 82.9%
Beside the measured number, compound 4's estimate is 20.9 percentage points below it, outside the stated range (above it).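

In this assay, the methoxy to hydroxy change on the core of compound 2 gives a number 4 percentage points higher from compound 2 to compound 4 (within the scatter). The same change therefore does not carry over unchanged from one core to the other: the same change on two cores in this assay, a number 20 percentage points lower (beyond the scatter) from compound 3 to compound 1 and a number 4 percentage points higher (within the scatter) from compound 2 to compound 4, 24 percentage points apart, beyond the scatter of two such steps. This shows that the outcome of the change depends on the core that carries it, but two pairs do not show which part of the core matters, or why.

The compounds shown carry only methoxy and hydroxy groups at the changed place, leaving open what a longer chain on that oxygen or an amine in its place would do. Also open, from the compounds shown here alone, is how the change would behave on a third core.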